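The source may report more compounds than this note shows. Statements on the series, on what has been measured and on what is new or still open speak of the compounds shown alone.

In a functional assay on A549 cells (Homo sapiens) for cytotoxicity, read by XTT assay, with a stated time of 72 h (on this read-out higher numbers stand for weaker inhibition and lower numbers for stronger inhibition), compound 3 `CCN(CC)C(=O)c1ccc(-c2cc(C3=CC(=O)C=CC3=O)no2)s1` gives 10000 nM. Compound 2 `CCN(CC)C(=O)c1ccc(-c2cc(-c3cc(OC)ccc3OC)no2)s1` gives 11000 nM in this assay, and the two numbers lie within the scatter of each other. Compound 1 `COc1ccc(OC)c(-c2cc(-c3ccc(C(=O)N4CCCC4)s3)on2)c1` gives only a limit in this assay, > 30000 nM. Among the measured compounds shown here, the single measured step alters the amine on the carbonyl carbon: an at least 2.7-fold lower number from compound 1 to compound 2 (0.43 log units; beyond the scatter). Compound 4 `CN(Cc1ccc(F)cc1)C(=O)c1ccc(-c2cc(C3=CC(=O)C=CC3=O)no2)s1` alters the same place, ((4-fluorobenzyl)(methyl)amino in place of diethylamino on a carbonyl carbon). That measured step shows the amine on the carbonyl carbon can shift the number, but it involves a different pair of groups, so for compound 4 only a modest shift in either direction is expected in this assay, a 1.7-fold lower number from compound 3 to compound 4 (0.22 log units; within the scatter). Compound 4 is therefore estimated at 6000 nM, expected to fall between 2000 nM and 20000 nM.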

Compound 4, half-maximal inhibitory concentration: > 30000 nM
Compound 4: a limit, no number; the forecaster's own chance of this, stated with the estimate: 10%; middle value at least 5.0-fold (0.69 log units) away from the limit.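

On the core of compound 3, the amine on the carbonyl carbon does matter: in this assay, an at least 3.0-fold higher number from compound 3 to compound 4 (0.47 log units; beyond the scatter). In both measured amine swaps, the pair's lower number belongs to the diethylamino compound, although the two pairs have different cores and different partner amines. Compound 4 gives only a limit, so the full size of this step stays unknown: the limit of > 30000 nM in this assay, at which 2 of the 4 values shown sit.

The step cannot separate the effects of the aromatic ring, its fluorine and the methyl. It also leaves open how a smaller amine, such as dimethylamino or morpholine, would read on this core.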